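Replacing the diethylamino group of compound 2

A few compounds are considered here, and "the series" means these few. Any claim that something is new, unique, unknown or untested is made for them only; others in the source may bear on it.

- Compound 1 `COc1ccc(C[C@H]2COC(=O)[C@@H]2Cc2ccc(OCc3cn(Cc4ccc(Cl)cc4)nn3)c(OC)c2)cc1OC`: 242000 nM
- Compound 2 `CCN(CC)C(=O)CCC(=O)Oc1ccc(C[C@H]2C(=O)OC[C@@H]2Cc2ccc(OC)c(OC)c2)cc1OC`: 213000 nM
- Compound 3 `COc1ccc(C[C@H]2COC(=O)[C@@H]2Cc2ccc(OCC(=O)Nc3ccc(C)cc3)c(OC)c2)cc1OC`: 228000 nM

In an ADME assay on HeLa cells (Homo sapiens) for cytotoxicity, read by MTT assay (a lower number here means a stronger inhibitor, a higher number a weaker inhibitor), compound 2 gives 213000 nM, which lies within the scatter of the values for compound 1 and compound 3. Compound 4 `COC(=O)[C@@H](NC(=O)CCC(=O)Oc1ccc(C[C@H]2C(=O)OC[C@@H]2Cc2ccc(OC)c(OC)c2)cc1OC)C(C)C` carries (1-(methoxycarbonyl)-2-methylpropyl)amino in place of diethylamino on a carbonyl carbon. Among the measured compounds shown here, the one measured step that bears on this change is a 1.1-fold higher number from compound 2 to compound 3 (0.03 log units; within the scatter). That step replaces the whole chain holding the diethylamino group, on an oxygen on an aromatic ring. No step beyond the scatter is therefore expected in this assay. The estimated step is a 1.0-fold higher number from compound 2 to compound 4 (0.01 log units; within the scatter). For compound 4 the expected value is 220000 nM, with an estimated range of 140000 nM to 330000 nM.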

Compound 4, half-maximal inhibitory concentration: 64000 nM
Estimate against measurement, compound 4: 3.4-fold (0.54 log units) above; the whole stated range lies above it.
By their numbers in this assay, from the lowest: compound 4; then compounds 2, 3 and 1 (each within the scatter of the next).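

In this assay, (1-(methoxycarbonyl)-2-methylpropyl)amino in place of diethylamino on a carbonyl carbon gives a 3.3-fold lower number from compound 2 to compound 4 (0.52 log units; beyond the scatter), whereas replacing the whole chain holding the diethylamino group gave a 1.1-fold higher number from compound 2 to compound 3 (0.03 log units; within the scatter) and no step beyond the scatter. The number is therefore not flat at this position: the group on this carbonyl carbon can move it beyond the scatter, and compound 4 has the lowest number of the series.

Going by these compounds, it remains open whether the step follows the methoxycarbonyl, the branched chain or the amide hydrogen, which a carboxylic acid in place of the methoxycarbonyl or a simple primary amide would begin to separate. No measurement here accounts for the step.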